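The source may hold more compounds than are shown below. What is called first, only, known or untested is meant among the compounds shown, and "the series" means these compounds.

In a functional assay for inhibition (on this read-out higher numbers stand for weaker inhibition and lower numbers for stronger inhibition), three compounds with a shared core have been measured, and they differ only in the group on a saturated chain carbon bound to an oxygen on an aromatic ring. Compound 1 (`CC(C)(C)c1cc(-c2cc(=O)c3ccc(OCCO)cc3o2)cc(C(C)(C)C)c1O`) gives 3000 nM. Compound 2 (`CC(C)(C)c1cc(-c2cc(=O)c3ccc(OCc4ccc(Cl)cc4)cc3o2)cc(C(C)(C)C)c1O`) gives 7000 nM. Compound 3 (`CC(C)(C)c1cc(-c2cc(=O)c3ccc(OCc4ccc5ccccc5n4)cc3o2)cc(C(C)(C)C)c1O`) gives 3000 nM, level with compound 1, and these two share the lowest of the three numbers.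

Compound 4 (`CN(C)CCCOc1ccc2c(=O)cc(-c3cc(C(C)(C)C)c(O)c(C(C)(C)C)c3)oc2c1`) has 2-(dimethylamino)ethyl in place of the quinolin-2-yl of compound 3: 2-(dimethylamino)ethyl in place of quinolin-2-yl on a saturated chain carbon bound to an oxygen on an aromatic ring.

Exchanging the group at this place has so far moved the number very little. The measured steps are a 2.3-fold higher number from compound 1 to compound 2 (0.37 log units; beyond the scatter), a 2.3-fold lower number from compound 2 to compound 3 (0.37 log units; beyond the scatter) and no change at the digits printed from compound 1 to compound 3 (within the scatter). Within the data shown here, no measured compound carries a dimethylamino group, so the data give no direct guide to this change. In this assay, a small step at most is therefore expected, with no firm direction and perhaps nothing beyond the scatter. The expected step is a 1.3-fold higher number from compound 3 to compound 4 (0.12 log units; within the scatter). For compound 4 the estimated value is 4000 nM, with an expected range from 1500 nM to 10000 nM.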

Compound 4, half-maximal inhibitory concentration: 700 nM
Compound 4: the middle estimate sits 5.7-fold (0.76 log units) above what was measured, and the stated range ends above it.
By their numbers in this assay, from the lowest: compound 4; then compounds 1 and 3 (each within the scatter of the next); then compound 2.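

In this assay the group at this place proves able to move the number more than the first three compounds showed: swapping the quinolin-2-yl for 2-(dimethylamino)ethyl gives a 4.3-fold lower number from compound 3 to compound 4 (0.63 log units; beyond the scatter) and clears the scatter, while replacing the 4-chlorophenyl gives a 10-fold lower number from compound 2 to compound 4 (1.00 log units; beyond the scatter) in the same direction. The hydroxy-ended chain is also surpassed, with a 4.3-fold lower number from compound 1 to compound 4 (0.63 log units; beyond the scatter) for (dimethylamino)methyl in place of hydroxy, so compound 4 is the strongest inhibitor of the four and a ring is not needed here for inhibition.

On these data alone, it remains open how much depends on the 3-(dimethylamino)propyl chain length or on the dimethylamino end, which a shorter or longer chain with that end, a piperidine or morpholine end, or a carboxylic acid end could test. Nothing available explains why this change lowers the number.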